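Methyl for methoxy on the carbonyl of compound 2

The source may report more compounds than this note shows. Statements on the series, on what has been measured and on what is new or still open speak of the compounds shown alone.

Working notes on a small set of indole-derived acrylic compounds tested in a functional assay on MT4 cells (Homo sapiens) for antiproliferative activity, read by MTT assay, with a stated time of 96 h; a lower number here means that less compound is needed, a higher number that more compound is needed for the effect. Compound 1 `CS(=O)(=O)/C(C#N)=C/c1c[nH]c2ccccc12` carries a nitrile and a methylsulfonyl group on the double bond and lacks the phenyl on the core; in this assay compound 1 reaches only the limit > 100000 nM, a limit of the assay and not a number (the limit of > 100000 nM in this assay, at which 1 of the 3 values shown sits). Compound 2 `COC(=O)/C(=C\c1c(-c2ccccc2)[nH]c2ccccc12)S(=O)(=O)c1ccccc1` gives 1000 nM in this assay. Compound 3 `N#C/C(=C\c1c(-c2ccccc2)[nH]c2ccccc12)C(=O)Nc1ccc(Cl)cc1`, with a nitrile and an anilide in place of the methoxycarbonyl and phenylsulfonyl pair, gives 1700 nM in this assay. Compound 2 thus holds the lower of the two numbers present, but its value and that of compound 3 sit within the scatter of each other, so no order between them can be read.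

Compound 4 `CC(=O)/C(=C\c1c(-c2ccccc2)[nH]c2ccccc12)S(=O)(=O)c1ccccc1` differs from compound 2 in one place: methyl in place of methoxy on a carbonyl carbon. Cut one bond further out, the change reads methoxycarbonyl to acetyl. With no measured step of this kind in the set, the expectation for this assay is a small step from compound 2 to compound 4, within the scatter, in either direction; a change of this size is estimated at a 1.5-fold higher number from compound 2 to compound 4 (0.18 log units; within the scatter). Compound 4 is therefore expected to give about 1500 nM in this assay, with a range from 500 nM to 5000 nM.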

Compound 4, half-maximal effective concentration: 400 nM
For compound 4 the middle estimate is 3.8-fold (0.57 log units) above the measured one; the measured number lies below the stated range.
By their numbers in this assay, from the lowest: compound 4; then compounds 2 and 3 (each within the scatter of the next). At a limit, above all of these: compound 1.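

Among the compounds shown here, compound 4 gives the series its first reading of a single change, since the earlier compounds differed from one another in more than one place. In this assay, the step of a 2.5-fold lower number from compound 2 to compound 4 (0.40 log units; beyond the scatter) is modest but lies beyond the scatter, so the group on this carbonyl carbon does affect the read-out even when the change is as small as methoxy to methyl, with the rest of the structure kept. The methoxy of compound 2 is therefore not needed to keep the effect, as the acetyl group of compound 4 serves at least as well here, and no measurement shown bears on why the number moves in this direction.

As far as these compounds go, how a longer chain such as ethyl, an amine giving an amide, or a hydroxy group giving a carboxylic acid would read on this same carbonyl carbon stays open, so the step cannot yet be placed in any wider trend. Also open, from the compounds shown here alone, is whether the same change gives a similar step when the phenylsulfonyl group is replaced by another group, such as a nitrile.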